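Benzyl added to a ketone-containing pepsin inhibitor

A few compounds are considered here, and "the series" means these few. Any claim that something is new, unique, unknown or untested is made for them only; others in the source may bear on it.

Measured compounds:
Compound 1, `CC(C)CCNC(=O)C(C)NC(=O)CC(=O)C(CC(C)C)NC(=O)C(NC(=O)CC(C)C)C(C)C`, gives 56 nM.
Compound 2, `CC(C)CCNC(=O)C(C)NC(=O)CCC(=O)[C@H](CC(C)C)NC(=O)C(NC(=O)CC(C)C)C(C)C`, gives 2140 nM.
Compound 3, `CC(C)CC(=O)NC(C(=O)N[C@@H](CC(C)C)[C@@H](O)CC(C)C(=O)NCC(=O)NC(=O)C(C)C)C(C)C`, gives 53 nM.

These three peptide-like compounds were tested in an assay on isolated protein for inhibition of Pepsin A (Sus scrofa); a higher number here means a weaker inhibitor, a lower number a stronger inhibitor. Compound 2 stands at the highest number of the three, so it is the weakest inhibitor here: its number lies well above that of compound 1 and above that of compound 3, and both gaps are beyond the usual scatter of this kind of measurement. Compound 1 and compound 3 sit close together, within the scatter of each other.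

Compound 4, `CC(C)CCNC(=O)C(C)NC(=O)[C@@H](CC(=O)[C@H](CC(C)C)NC(=O)C(NC(=O)CC(C)C)C(C)C)Cc1ccccc1`, has not yet been measured. It differs from compound 2 in one place: benzyl in place of hydrogen on a saturated chain carbon bound to a carbonyl carbon and a saturated chain carbon. That carbon, which in compound 2 carries only hydrogens, therefore gains a side chain in compound 4, while everything else in the molecule stays the same.

Among the compounds with values here, no measured pair shows what such a change does in [this assay] , so the expectation rests only on the weak standing of compound 2 at 2140 nM. A step from compound 2 to compound 4 of an 18-fold lower number from compound 2 to compound 4 (1.25 log units; beyond the scatter) toward a stronger inhibitor is expected, since the room for improvement is large. Compound 4 is estimated at 120 nM, with a range from 20 nM to 800 nM.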

Compound 4, inhibition constant: 850 nM
The estimate for compound 4 lay 7.1-fold (0.85 log units) below the measured number, and the stated range ends below it.
By their numbers in this assay, from the lowest: compounds 3 and 1 (each within the scatter of the next); then compound 4; then compound 2.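

Putting benzyl in place of hydrogen on this saturated chain carbon, bound to a carbonyl carbon and a saturated chain carbon, gives a 2.5-fold lower number from compound 2 to compound 4 (0.40 log units; beyond the scatter) in this assay. This shows that the carbon, which carries only hydrogens in compound 2, can bear a side chain of 7 heavy atoms with one six-membered aromatic ring, and that the inhibitor becomes modestly stronger rather than weaker. Nothing among the data shown accounts for the size of this step.

The compounds shown leave open whether the aromatic ring matters or any added carbon chain would give a similar step, a question that a simple methyl, a longer chain without a ring, or a phenyl group set directly on this carbon could help to answer. They also leave open how an amine or a carboxylic acid on the same carbon would compare, and what the mirror-image arrangement of the benzyl group at this carbon would do to the number.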